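The source may hold more compounds than are shown below. What is called first, only, known or untested is meant among the compounds shown, and "the series" means these compounds.

In a functional assay on A-375 cells (Homo sapiens) for inhibition, read by CCK-8 assay, with a stated time of 72 h, tested at 8 uM (a lower number here means less inhibition of growth, a higher number more inhibition of growth at the concentration tested), compound 3 `Nc1ccccc1NC(=O)/C=C/c1ccc(CSc2cccc(F)c2)cc1` gives 9.08%. That value lies within the scatter of compound 1 `Cc1cc(C)cc(SCc2ccc(/C=C/C(=O)Nc3ccccc3N)cc2)c1`, which gives 2.49%, as a number 6.6 percentage points higher from compound 1 to compound 3 (within the scatter) shows. Compound 2 `Nc1ccccc1NC(=O)/C=C/c1ccc(CSc2ccc(Cl)cc2)cc1` stands clear of both at 48.2%.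

The next change is 5-(trifluoromethyl)pyridin-2-yl in place of 3-fluorophenyl on a sulfur. It leads to compound 4 `Nc1ccccc1NC(=O)/C=C/c1ccc(CSc2ccc(C(F)(F)F)cn2)cc1`, with 5-(trifluoromethyl)pyridin-2-yl in place of 3-fluorophenyl on a sulfur.

Three measured steps change this same group. Two are large, a number 45.7 percentage points higher from compound 1 to compound 2 (beyond the scatter) and a number 39.1 percentage points lower from compound 2 to compound 3 (beyond the scatter), and both involve compound 2, so the group on the sulfur can move the number widely. The third, a number 6.6 percentage points higher from compound 1 to compound 3 (within the scatter), goes against any rule that swapping this group always matters. Among the measured compounds shown here, no measured compound carries the entering group, so these steps transfer only loosely. A moderate rise is the working expectation, smaller than the large steps and with wide uncertainty.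

The expected step is a number 18.9 percentage points higher from compound 3 to compound 4 (beyond the scatter). For compound 4 the estimated value is 28%, with an expected range of 6% to 58%.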

Compound 4, percent growth inhibition at one concentration: 3.96%
The estimate for compound 4 lay 24 percentage points above the measured number; measured number outside the range, below it.
By their numbers in this assay, from the lowest: compounds 1, 4 and 3 (each within the scatter of the next); then compound 2.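

In this assay the ring nitrogen and trifluoromethyl group of the entering 5-(trifluoromethyl)pyridin-2-yl leave the number within the scatter of the two other low compounds: a number 5.1 percentage points lower from compound 3 to compound 4 (within the scatter) and a number 1.5 percentage points higher from compound 1 to compound 4 (within the scatter) are both small steps. With a number 44.2 percentage points lower from compound 2 to compound 4 (beyond the scatter) as the remaining new step, every large step on this sulfur now involves compound 2, so among these four groups only 4-chlorophenyl stands apart. No supporting measurement bears on this result.

The compounds shown leave open whether the high number of compound 2 needs chlorine or tolerates another halogen, as in 4-bromophenyl, and whether it survives moving the chlorine, as in 3-chlorophenyl. A 5-chloropyridin-2-yl group on the same sulfur would show whether the ring nitrogen can be carried alongside chlorine.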